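The source may hold more compounds than are shown below. What is called first, only, known or untested is meant among the compounds shown, and "the series" means these compounds.

Of the compounds shown here, three built on one shared core have been tested in an ADME assay on TZM cells (Homo sapiens) for cytotoxicity, read by CellTiter-Glo, with a stated time of 48 h; a higher number here means that more compound is tolerated, a lower number that less compound is tolerated. Compound 1 `COc1ccc(C2=Cc3ccc(F)cc3C(CC(=O)CO)N2c2ccc(O)cc2)cc1` gives 47700 nM. Compound 2 `COc1ccc(C2=Cc3ccc(F)cc3C(CC(=O)CO)N2c2ccc([N+](=O)[O-])cc2)cc1` differs from compound 1 by nitro in place of hydroxy on an aromatic carbon, and in this assay compound 2 gives 46400 nM, a step of a 1.0-fold lower number from compound 1 to compound 2 (0.01 log units; within the scatter). Compound 3 `COc1ccc(C2=Cc3ccc(F)cc3C(CC(=O)C(C)O)N2c2ccc(O)cc2)cc1` differs from compound 1 by methyl in place of hydrogen on a saturated chain carbon bound to a carbonyl carbon and an oxygen on a saturated carbon, and in this assay compound 3 gives 50900 nM, a step of a 1.1-fold higher number from compound 1 to compound 3 (0.03 log units; within the scatter). Compound 4 `COc1ccc(C2=Cc3ccc(F)cc3C(CC(=O)C(C)O)N2c2ccc([N+](=O)[O-])cc2)cc1` has not yet been measured. It differs from compound 3 by nitro in place of hydroxy on an aromatic carbon, the same change as that from compound 1 to compound 2, made on a core that differs by methyl in place of hydrogen on a saturated chain carbon bound to a carbonyl carbon and an oxygen on a saturated carbon. Because the earlier change gave a 1.0-fold lower number from compound 1 to compound 2 (0.01 log units; within the scatter), compound 4 is expected to show a step of similar size, a 1.0-fold lower number from compound 3 to compound 4 (0.02 log units; within the scatter). Compound 4 is therefore estimated at 49000 nM, with a range from 30000 nM to 80000 nM.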

Compound 4, half-maximal cytotoxic concentration: 10100 nM
Compound 4: middle estimate off by 4.9-fold (0.69 log units), on the high side; measured number outside the range, below it.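

In this assay, nitro in place of hydroxy gives a 5.0-fold lower number from compound 3 to compound 4 (0.70 log units; beyond the scatter), so on the core carrying the extra methyl this change does not behave as it did on the core of compound 1: the same change on two cores in this assay, a 1.0-fold lower number (0.01 log units; within the scatter) from compound 1 to compound 2 and a 5.0-fold lower number (0.70 log units; beyond the scatter) from compound 3 to compound 4, 4.9-fold (0.69 log units) apart, beyond the scatter of two such steps Read the other way, adding the methyl gives a 4.6-fold lower number from compound 2 to compound 4 (0.66 log units; beyond the scatter), so its step also depends on which group sits on the aromatic ring: the same change on two cores in this assay, a 1.1-fold higher number (0.03 log units; within the scatter) from compound 1 to compound 3 and a 4.6-fold lower number (0.66 log units; beyond the scatter) from compound 2 to compound 4, 4.9-fold (0.69 log units) apart, beyond the scatter of two such steps Within these four compounds, the two changes therefore do not simply add up, but one pair on each side does not explain why or set a rule for other cores.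

As far as these compounds go, it remains open whether an amine or a carboxylic acid in place of the nitro, or a longer chain in place of the methyl, would show a similar step.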